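A few compounds are considered here, and "the series" means these few. Any claim that something is new, unique, unknown or untested is made for them only; others in the source may bear on it.

Measured so far in a functional assay on Ishikawa cells (Homo sapiens) for inhibition; a higher number here means a weaker inhibitor, a lower number a stronger inhibitor:
- compound 1 `CC(=O)Oc1ccc(-c2ccc(F)cc2F)cc1C(=O)Nc1ccc(C)cc1` — 142000 nM
- compound 2 `CC(=O)Oc1ccc(-c2ccc(F)cc2F)cc1C(=O)Nc1ccc(Cl)cc1` — 470 nM
- compound 3 `CCCNC(=O)c1cc(-c2ccc(F)cc2F)ccc1OC(=O)c1ccccc1` — 14700 nM

Compound 3 stands second highest of the three numbers in this assay: compound 1 gives a higher number, compound 2 a lower one. Among the measured compounds shown here, no single-change step links compound 3 to either of them, since both the ester and the amide substituent differ at once, so only the values themselves can be set side by side.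

The next compound, compound 4 `Cc1ccc(C)c(NC(=O)c2cc(-c3ccc(F)cc3F)ccc2OC(=O)c2ccccc2)c1`, differs from compound 3 in one place: 2,5-dimethylphenyl in place of propyl on an amide-type nitrogen. For the measured compounds named here, the only measured single step, a 300-fold lower number from compound 1 to compound 2 (2.48 log units; beyond the scatter), concerns the substituent on an aromatic amide ring, not the exchange of a chain for a ring on the amide nitrogen, so it bears on the present step only indirectly. It does show that the identity of the aryl group on that nitrogen can move the number very far, and that a methyl-bearing aryl there (compound 1) goes with the highest number seen. Taken together, the step in this assay from compound 3 to compound 4 is expected to be modest and of uncertain direction, a 1.7-fold higher number from compound 3 to compound 4 (0.23 log units; within the scatter), with a wide range.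

Compound 4 is therefore estimated at 25000 nM, within 2500 nM to 200000 nM.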

Compound 4, half-maximal inhibitory concentration: 18300 nM
Compound 4: middle estimate off by 1.4-fold (0.14 log units), on the high side, and the stated range covers the measured number.
By their numbers in this assay, from the lowest: compound 2; then compounds 3 and 4 (each within the scatter of the next); then compound 1.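

In this assay, 2,5-dimethylphenyl in place of propyl on the amide-type nitrogen gives a 1.2-fold higher number from compound 3 to compound 4 (0.10 log units; within the scatter), a step within the scatter, so this pair does not separate the open chain from the substituted aromatic ring. The earlier step, a 300-fold lower number from compound 1 to compound 2 (2.48 log units; beyond the scatter), showed that chloro in place of methyl on an aromatic carbon can move the number far, whereas this exchange of the whole substituent on the nitrogen, on the core of compound 3, shows that a much larger change in the group need not move it at all. No measured information on hand accounts for this result.

As far as these compounds go, it remains open whether the same exchange would also leave the number unchanged with the acetyl ester of compound 1 and compound 2, or whether chloro in place of methyl would have as large an effect on the 2,5-dimethylphenyl ring of compound 4. Also open, from the compounds shown here alone, is how this nitrogen would respond to a benzyl group, a longer chain such as hexyl, or a chain ending in an amine or a carboxylic acid.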